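A few compounds are considered here, and "the series" means these few. Any claim that something is new, unique, unknown or untested is made for them only; others in the source may bear on it.

The study concerns two measured compounds and a third awaiting measurement, all built on one shared core. Compound 1 `O=c1nc2ccc(Br)cn2cc1Cc1ccccc1` carries a single bromine. In a functional assay on MCF7 cells (Homo sapiens) for cytotoxicity, read by MTT assay, with a stated time of 24 h (on this read-out higher numbers stand for weaker inhibition and lower numbers for stronger inhibition), compound 1 gives only a limit, > 1000000 nM, and this is the limit of > 1000000 nM in this assay, at which 1 of the 2 values shown sits, rather than a number. Compound 2 `O=c1nc2ccccn2cc1Cc1ccc(Br)cc1` carries its single bromine elsewhere on the core, and in this assay compound 2 gives 157000 nM. Among the compounds with values here, compound 2 is therefore the only compound of the two with an actual number in this assay; the other value shown is a limit.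

Compound 3 `O=c1nc2ccc(Br)cn2cc1Cc1ccc(Br)cc1` carries both bromines. It differs from compound 2 by bromo in place of hydrogen on an aromatic carbon. No measured pair differs in this one place alone, so the size of the step is not known from the numbers shown. Compound 1, which carries the same bromo without the other, sits at a limit, and nothing in the data ties that limit to this change alone. The step from compound 2 to compound 3 is expected to be small or, if anything, toward weaker inhibition, a 1.6-fold higher number from compound 2 to compound 3 (0.20 log units; within the scatter). Compound 3 is expected to give about 250000 nM in this assay, within a range of 60000 nM to 1000000 nM.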

Compound 3, half-maximal inhibitory concentration: 97200 nM
For compound 3 the middle estimate is 2.6-fold (0.41 log units) above the measured one; the range from low to high includes it.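

In this assay, bromo on an aromatic carbon of the six-membered aromatic ring with 1 nitrogen, two atoms from the ring nitrogen, does not shift the number beyond the scatter when the other bromo is already present, with a 1.6-fold lower number from compound 2 to compound 3 (0.21 log units; within the scatter). The change at the other place, with the bromo at this position already present, is the larger one, with an at least 10-fold lower number from compound 1 to compound 3 (1.01 log units; beyond the scatter), so among these compounds it is the bromo shared by compound 2 and compound 3 that goes with a measurable number, while the bromo at this position does not. The size of that larger step has only a bound, since compound 1 gives a limit and not a number: the limit of > 1000000 nM in this assay, at which 1 of the 3 values shown sits.

What the compounds leave open is whether a group other than bromo at this position, such as an amine or a carboxylic acid, would move the number beyond the scatter. Also open, as far as these compounds go, is whether a methoxy group or a longer chain in place of the other bromo would keep a measurable number in this assay.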